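Iodo to trifluoromethoxy on the shared core

A few compounds are considered here, and "the series" means these few. Any claim that something is new, unique, unknown or untested is made for them only; others in the source may bear on it.

In a functional assay (aorta) for inhibition, with Rattus norvegicus as the target (on this read-out higher numbers stand for an effect only at larger amounts of compound and lower numbers for an effect already at smaller amounts), compound 1 (`O=C1C(Nc2ccc(Cl)cc2)=CC(=O)c2ncccc21`) gives 178 nM and compound 2 (`O=C1C(Nc2ccc(I)cc2)=CC(=O)c2ncccc21`) gives 214 nM. Among the compounds with values here, these are the only two numbers so far, and they lie within the scatter of each other, so compound 2 cannot be separated from compound 1. Compound 3 (`O=C1C(Nc2ccc(OC(F)(F)F)cc2)=CC(=O)c2ncccc21`) has yet to be measured. It carries trifluoromethoxy in place of iodo on an aromatic carbon, para to a large group: trifluoromethoxy in place of iodo on an aromatic carbon. Within the data shown here, one measured step bears on this change, and only indirectly. Iodo in place of chloro on an aromatic carbon gave a 1.2-fold higher number from compound 1 to compound 2 (0.08 log units; within the scatter). Among the measured compounds shown here, no measured compound carries trifluoromethoxy, so that small step is a thin guide and the range is kept wide. For the measured compounds named here, with this step as the only evidence, no change beyond the scatter is expected in this assay, in either direction. The expected step is a 1.1-fold lower number from compound 2 to compound 3 (0.03 log units; within the scatter). For compound 3 the estimated value is 200 nM, with an expected range from 70 nM to 600 nM.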

Compound 3, half-maximal effective concentration: 603 nM
The estimate for compound 3 lay 3.0-fold (0.48 log units) below the measured number; the whole stated range lies below it.
By their numbers in this assay, from the lowest: compounds 1 and 2 (each within the scatter of the next); then compound 3.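

In this assay, trifluoromethoxy in place of iodo gives a 2.8-fold higher number from compound 2 to compound 3 (0.45 log units; beyond the scatter), and trifluoromethoxy in place of chloro gives a 3.4-fold higher number from compound 1 to compound 3 (0.53 log units; beyond the scatter). The number at this place on the aromatic ring is therefore not indifferent to what sits there: the exchange of the two halogens stayed within the scatter, whereas this exchange of a halogen for trifluoromethoxy moves the number beyond it, though only modestly, and leaves compound 3 with the highest number of the three. Nothing measured here accounts for the rise, so the data show its direction and size but give no reason for it.

With only one group other than a halogen at this place, the compounds shown leave open whether the rise belongs to trifluoromethoxy itself or would also appear with other groups that are not halogens, such as methoxy or an amine. They also leave open whether a group at this place can bring the number below those of compound 1 and compound 2, and whether plain hydrogen there would stay close to those two halogen compounds.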